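The compounds below may be only part of what the source reports. "The series", "measured", "known", "first", "only" and "open" are said of these compounds alone.

Compound 1 `CN1CCN(C(=O)/C=C/c2ccncc2-c2ccc3ccccc3c2)CC1`: 101%
Compound 2 `O=C(O)[C@@H]1CCCN1C(=O)/C=C/c1ccncc1-c1ccc2ccccc2c1`: 67%
Compound 3 `NNC(=O)COc1ccncc1-c1ccc2ccccc2c1`: 19%

All three were tested in an assay on a protein complex for inhibition of CDK8/Cyclin C (Homo sapiens), with a stated time of 1 h, tested at 10 uM; on this read-out lower numbers stand for less inhibition and higher numbers for more inhibition at the one concentration tested (going by the name of the read-out). Compound 3 stands lowest of the three numbers; its nearest neighbour is compound 2, with a gap beyond the scatter, and compound 1 lies further away still. For the measured compounds named here, the only measured step, a number 34 percentage points lower from compound 1 to compound 2 (beyond the scatter), alters just the group on the carbonyl carbon and leaves the rest of the molecule untouched, so it does not bear directly on the change examined here.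

Compound 4 `O=C(O)/C=C/c1ccncc1-c1ccc2ccccc2c1` differs from compound 3 by 2-carboxyethenyl in place of (aminocarbamoyl)methoxy on an aromatic carbon. Going by the values given here, no measured pair makes this exact change. What can be said is that compounds 1 and 2, which both carry an ethenyl-carbonyl chain at this position like compound 4, give the two higher numbers, while compound 3 with its methoxy-linked chain gives the lowest. On that slender basis a rise is expected. Compound 4 is expected to give about 45%, within a range from 15% to 80%. The step this estimate means, a number 26 percentage points higher from compound 3 to compound 4 (beyond the scatter), is expected to lie beyond the scatter.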

Compound 4, a percentage reported as inhibition, at one concentration (the size of the read-out at that concentration, not a potency): 102%
Beside the measured number, compound 4's estimate is 57 percentage points below it; measured number above the stated range.
By their numbers in this assay, from the lowest: compound 3; then compound 2; then compounds 1 and 4 (each within the scatter of the next).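

Putting 2-carboxyethenyl in place of (aminocarbamoyl)methoxy on this aromatic carbon, opposite the ring nitrogen, changes the result strongly (a number 83 percentage points higher from compound 3 to compound 4 (beyond the scatter)). On the carbonyl carbon of the chain, hydroxy and 4-methylpiperazin-1-yl cannot be told apart (a number 1 percentage points higher from compound 1 to compound 4 (within the scatter)), while 2-carboxypyrrolidin-1-yl stands apart from hydroxy (a number 35 percentage points higher from compound 2 to compound 4 (beyond the scatter)), so the group on that carbonyl matters, but not every change to it makes a difference. Nothing measured here explains why these groups differ.

On these data alone, it remains open whether the double bond of the chain matters, which a 2-carboxyethyl group on the same aromatic carbon could test. As far as these compounds go, it is also open how a simple primary amide or a small amine such as dimethylamine on the carbonyl carbon would compare with hydroxy and 4-methylpiperazin-1-yl.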